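The source may report more compounds than this note shows. Statements on the series, on what has been measured and on what is new or still open speak of the compounds shown alone.

Of the compounds shown here, two that share one core have been tested in a functional assay on MDA-MB-231 cells (Homo sapiens) for inhibition, read by MTT assay, with a stated time of 48 h; a lower number here means a stronger inhibitor, a higher number a weaker inhibitor. Compound 1 `CC(C)n1c(/C=C2\SC(=O)N(CC(=O)N3CCCCC3)C2=O)nc2ccccc21` gives in this assay only a limit, > 50000 nM. Compound 2 `CCn1c(/C=C2\SC(=O)N(CC(=O)N3CCCC3)C2=O)nc2ccccc21` likewise gives in this assay only a limit, > 50000 nM. For the measured compounds named here, both values sit at the limit of > 50000 nM in this assay, at which 2 of the 2 values shown sit, so no measured step between them is known. Compound 3 `CCn1c(/C=C2\SC(=O)N(CC(=O)N3CCCCC3)C2=O)nc2ccccc21` differs from compound 2 in one place: piperidin-1-yl in place of pyrrolidin-1-yl on a carbonyl carbon. Compound 1 also carries piperidin-1-yl on that carbonyl carbon and in this assay gives only the limit > 50000 nM. The expected step is therefore a step that the limit leaves unreadable from compound 2 to compound 3, none beyond the scatter. Compound 3 is expected at about 80000 nM, between 30000 nM and 250000 nM, most likely again only a limit.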

Compound 3, half-maximal inhibitory concentration: > 50000 nM
Compound 3: no number, only a limit; the forecaster's own chance of this, stated with the estimate: 85%; the middle value lies beyond the limit too.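

Compound 3 gives only a limit in this assay, as do compound 1 and compound 2, so no step from either to compound 3 can be read: the limit of > 50000 nM in this assay, at which 3 of the 3 values shown sit.

The compounds shown leave open whether piperidin-1-yl and pyrrolidin-1-yl differ at all in this measure of inhibition.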